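Replacing 4-nitrophenyl with 2-bromophenyl in compound 1

A few compounds are considered here, and "the series" means these few. Any claim that something is new, unique, unknown or untested is made for them only; others in the source may bear on it.

Among the measured compounds shown here, in an ADME assay on HEK293 cells (Homo sapiens) for cytotoxicity, read by MTT assay, with a stated time of 68 h (a higher number here means a weaker inhibitor, a lower number a stronger inhibitor), compound 1 `O=C(/C=C/c1cccc(OCc2ccccc2)c1)c1ccc([N+](=O)[O-])cc1` gives 59300 nM, the highest number among the three compounds measured so far. Compound 2 `O=C(/C=C/c1cccc(OCc2ccccc2)c1)c1ccc(Cl)cc1Cl` gives 24900 nM, and compound 3 `O=C(/C=C/c1cccc(OCc2ccccc2)c1)c1ccc(Br)cc1` gives 5400 nM. The unmeasured compound 4 `O=C(/C=C/c1cccc(OCc2ccccc2)c1)c1ccccc1Br` keeps the core of compound 1 but changes the group on the carbonyl carbon: 2-bromophenyl in place of 4-nitrophenyl on a carbonyl carbon.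

For the measured compounds named here, no measured compound carries this exact group, so two steps serve as guides. Putting 2,4-dichlorophenyl in place of 4-nitrophenyl gave a 2.4-fold lower number from compound 1 to compound 2 (0.38 log units; beyond the scatter), a modest step, while bromo in place of nitro gave an 11-fold lower number from compound 1 to compound 3 (1.04 log units; beyond the scatter), a large one. Both steps lowered the number, but the guides differ from each other, with a 4.6-fold lower number from compound 2 to compound 3 (0.66 log units; beyond the scatter). Compound 4 shares its bromo group with compound 3 and has a halogen at the 2 position, as compound 2 does, so a step between these two sizes seems reasonable. The expected change is a 4.9-fold lower number from compound 1 to compound 4 (0.69 log units; beyond the scatter). For compound 4 the estimate is 12000 nM, with an expected range of 4000 nM to 35000 nM.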

Compound 4, half-maximal inhibitory concentration: 2200 nM
For compound 4 the middle estimate is 5.5-fold (0.74 log units) above the measured one, and the stated range ends above it.
By their numbers in this assay, from the lowest: compound 4; then compound 3; then compound 2; then compound 1.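

In this assay, the place of the bromo group on the ring matters: 2-bromophenyl in place of 4-bromophenyl gives a 2.5-fold lower number from compound 3 to compound 4 (0.39 log units; beyond the scatter), even though the two groups have the same atoms. The change from 4-nitrophenyl gives a 27-fold lower number from compound 1 to compound 4 (1.43 log units; beyond the scatter), the largest step seen at this carbonyl carbon, and the change from 2,4-dichlorophenyl gives an 11-fold lower number from compound 2 to compound 4 (1.05 log units; beyond the scatter), so these two halogen-bearing groups are far from interchangeable here. No measurement is available to explain why these groups differ.

Still open, as far as these compounds go, is whether 2-chlorophenyl would behave like 2-bromophenyl, which would show whether the bromine itself matters, and how a ring carrying an amine or a carboxylic acid would compare. From the compounds shown here alone, all four compounds also share the core of compound 1, so it is unknown whether this order would hold on a different core.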